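Amide nitrogen methyl versus hydrogen in two cores

The source may hold more compounds than are shown below. What is called first, only, known or untested is meant among the compounds shown, and "the series" means these compounds.

Measured compounds:
compound 1 `CN(Cc1cc(C(F)(F)F)cc(C(F)(F)F)c1)C(=O)c1c(-c2ccc(F)cc2)c2cccnc2c(=O)n1C`: 0.21 nM
compound 2 `Cn1c(C(=O)NCc2cc(C(F)(F)F)cc(C(F)(F)F)c2)c(-c2ccc(F)cc2)c2cccnc2c1=O`: 1.1 nM
compound 3 `Cc1ccccc1-c1c(C(=O)N(C)Cc2cc(C(F)(F)F)cc(C(F)(F)F)c2)n(C)c(=O)c2ccccc12`: 1.3 nM

In an assay on IM-9 cells for binding affinity to Substance-P receptor (Homo sapiens) (on this read-out higher numbers stand for weaker inhibition and lower numbers for stronger inhibition), compound 1 gives 0.21 nM, and compound 2 gives 1.1 nM. The change between them is hydrogen in place of methyl on an amide-type nitrogen, and the step is a 5.2-fold higher number from compound 1 to compound 2 (0.72 log units; beyond the scatter). Compound 3 carries a different core; the difference between the core of compound 1 and the core of compound 3 is not broken down here. In this assay compound 3 gives 1.3 nM, which lies within the scatter of the value of compound 2 and beyond it relative to compound 1.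

Compound 4 `Cc1ccccc1-c1c(C(=O)NCc2cc(C(F)(F)F)cc(C(F)(F)F)c2)n(C)c(=O)c2ccccc12` is not yet measured. It differs from compound 3 by hydrogen in place of methyl on an amide-type nitrogen, the same change as that from compound 1 to compound 2, at a nitrogen with the same neighbours. Going by the values given here, the step from compound 3 to compound 4 is expected to be a 4.6-fold higher number from compound 3 to compound 4 (0.66 log units; beyond the scatter), of a size close to the earlier one, because a 5.2-fold higher number from compound 1 to compound 2 (0.72 log units; beyond the scatter) is the only measured instance of this change, and it rests on a single pair, so the range is kept wide. For compound 4 in this assay the estimate is 6 nM, with a range from 2 nM to 20 nM.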

Compound 4, half-maximal inhibitory concentration: 2.5 nM
The estimate for compound 4 lay 2.4-fold (0.38 log units) above the measured number; the range from low to high includes it.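

Swapping methyl for hydrogen on the amide-type nitrogen does not carry over at a constant size from one core to the other in this assay, since the two steps differ by more than the scatter: the same change on two cores in this assay, a 5.2-fold higher number (0.72 log units; beyond the scatter) from compound 1 to compound 2 and a 1.9-fold higher number (0.28 log units; within the scatter) from compound 3 to compound 4, 2.7-fold (0.44 log units) apart, beyond the scatter of two such steps. The new step is a 1.9-fold higher number from compound 3 to compound 4 (0.28 log units; within the scatter), so on the core of compound 3 the change cannot be told apart from repeat-measurement noise, whereas on the core of compound 1 it stands clear of it. These two pairs show that a step measured on one core is a poor guide to its size on the other, but they do not show which structural difference between the pairs is responsible, nor how the change would behave on a third core.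

On these data alone, only methyl and hydrogen appear on this nitrogen, so the effect of an ethyl group or a longer chain there remains open. Also open, as far as these compounds go, is whether a chain ending in an amine would be tolerated at that nitrogen on either core.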